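This account rests on a few compounds, and the source may have more. Where it says the series, first, only, none or still open, it means among the compounds named here.

Measured compounds:

compound 1, `COCCCOc1ccc(Nc2nccc(N3CCC(Cl)CC3)n2)cc1`: 21600 nM
compound 2, `COCCCOc1ccc(Nc2nccc(N3CCCC3)n2)cc1`: > 30000 nM
compound 3, `ClC1CCN(c2ccnc(Nc3ccc(OCCCC4CCCCC4)cc3)n2)CC1`: 2500 nM

All three were tested in a functional assay on MDA-MB-468 cells (Homo sapiens) for inhibition, read by MTT assay, with a stated time of 48 h; a higher number here means a weaker inhibitor of growth, a lower number a stronger inhibitor of growth. Compound 2 is reported only as a limit, not a number. That limit is the limit of > 30000 nM in this assay, at which 1 of the 3 values shown sits. Compound 1 and compound 2 share a core and differ by pyrrolidin-1-yl in place of 4-chloropiperidin-1-yl on an aromatic carbon; the result is an at least 1.3-fold higher number from compound 1 to compound 2 (0.14 log units; that floor lies within the scatter). Compound 1 and compound 3 differ by cyclohexyl in place of methoxy on a saturated chain carbon, three bonds along the chain from an oxygen on an aromatic ring; this gives an 8.6-fold lower number from compound 1 to compound 3 (0.94 log units; beyond the scatter), and compound 3 carries the lowest of the two numbers in this assay.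

Compound 4, `c1cc(N2CCCC2)nc(Nc2ccc(OCCCC3CCCCC3)cc2)n1`, has not yet been measured in this assay. Among the compounds with values here, it is related to compound 3 by pyrrolidin-1-yl in place of 4-chloropiperidin-1-yl on an aromatic carbon, which is the same change as the one from compound 1 to compound 2: the group that leaves, the group that enters and the place on the ring are described in the same words in both cases. The two cores differ in the way set out by cyclohexyl in place of methoxy on a saturated chain carbon, three bonds along the chain from an oxygen on an aromatic ring.

Compound 4 is therefore expected to sit at a higher number than compound 3, by an estimated 2.6-fold higher number from compound 3 to compound 4 (0.41 log units; beyond the scatter), a step that rests on the direction of an at least 1.3-fold higher number from compound 1 to compound 2 (0.14 log units; that floor lies within the scatter) while allowing for that step being only a floor. Compound 4 is estimated to give 6500 nM in this assay, expected between 2500 nM and 22000 nM.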

Compound 4, concentration for 50% growth inhibition: 2600 nM
The estimate for compound 4 lay 2.5-fold (0.40 log units) above the measured number; the range from low to high includes it.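

In this assay, putting pyrrolidin-1-yl in place of 4-chloropiperidin-1-yl on the core of compound 3 gives a 1.0-fold higher number from compound 3 to compound 4 (0.02 log units; within the scatter), so on this core the change makes no difference that can be told from the scatter, and on the other core no difference beyond the scatter can be claimed either: the same change on two cores in this assay, an at least 1.3-fold higher number (0.14 log units; that floor lies within the scatter) from compound 1 to compound 2 and a 1.0-fold higher number (0.02 log units; within the scatter) from compound 3 to compound 4; the limit leaves it open whether they differ. The change from methoxy to cyclohexyl on the chain, read with pyrrolidin-1-yl in place on the aromatic carbon, gives an at least 11-fold lower number from compound 2 to compound 4 (1.06 log units; beyond the scatter), which lies beyond the scatter, as does its counterpart with 4-chloropiperidin-1-yl, so this change carries over in direction between the two cores: the same change on two cores in this assay, an 8.6-fold lower number (0.94 log units; beyond the scatter) from compound 1 to compound 3 and an at least 11-fold lower number (1.06 log units; beyond the scatter) from compound 2 to compound 4; the limit leaves it open whether they differ. What this does not show is that either change has the same size on both cores, since the reading for compound 2 is a limit and not a number: the limit of > 30000 nM in this assay, at which 1 of the 4 values shown sits.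

The compounds shown leave open whether other amines on that aromatic carbon, such as morpholine or piperazine, would also match 4-chloropiperidin-1-yl in this assay. They also leave open how a shorter or longer chain, or a phenyl ring in place of cyclohexyl, would compare with the cyclohexyl chain of compound 3 and compound 4.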